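Moving the methoxy group to the fourth position of the benzyl ring

The source may hold more compounds than are shown below. What is called first, only, known or untested is meant among the compounds shown, and "the series" means these compounds.

Compound 3 `COc1cccc(COc2ccc(-c3cc(CN4CCN(Cc5ccc(C(F)(F)F)cc5)CC4)no3)cc2)c1` gives 2000 nM in a functional assay on MCF7 cells (Homo sapiens) for antiproliferative activity, read by sulforhodamine B assay, with a stated time of 72 h (on this read-out higher numbers stand for weaker inhibition and lower numbers for stronger inhibition), the highest number of the three measured, against 300 nM for compound 2 `COc1ccccc1COc1ccc(-c2cc(CN3CCN(Cc4ccc(C(F)(F)F)cc4)CC3)no2)cc1` and 100 nM for compound 1 `N#Cc1ccc(COc2ccc(-c3cc(CN4CCN(Cc5ccc(C(F)(F)F)cc5)CC4)no3)cc2)cc1`. Compound 4 `COc1ccc(COc2ccc(-c3cc(CN4CCN(Cc5ccc(C(F)(F)F)cc5)CC4)no3)cc2)cc1` differs from compound 3 by 4-methoxyphenyl in place of 3-methoxyphenyl on a saturated chain carbon bound to an oxygen on an aromatic ring. Within the data shown here, the steps that bear on this are a 6.7-fold higher number from compound 2 to compound 3 (0.82 log units; beyond the scatter), which shows how much the position of the methoxy group matters, and a 20-fold higher number from compound 1 to compound 3 (1.30 log units; beyond the scatter), where a 4-substituted benzyl ring gave the lowest number. Since compound 1 and compound 2 both sit well below compound 3, a step back down toward them is expected; the estimate for compound 4 is a step of a 5.0-fold lower number from compound 3 to compound 4 (0.70 log units; beyond the scatter), giving about 400 nM with a range from 120 nM to 1500 nM.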

Compound 4, half-maximal inhibitory concentration: 1300 nM
The estimate for compound 4 lay 3.3-fold (0.51 log units) below the measured number, within the range that was stated.
By their numbers in this assay, from the lowest: compound 1; then compound 2; then compounds 4 and 3 (each within the scatter of the next).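

In this assay, 4-methoxyphenyl in place of 3-methoxyphenyl gives a 1.5-fold lower number from compound 3 to compound 4 (0.19 log units; within the scatter), so these two placements of the methoxy group are not told apart, while the 2-methoxyphenyl compound remains distinct, with a 4.3-fold higher number from compound 2 to compound 4 (0.64 log units; beyond the scatter) in this comparison. Methoxy in place of cyano on an aromatic carbon gives a 13-fold higher number from compound 1 to compound 4 (1.11 log units; beyond the scatter) and shows that the low number of compound 1 does not carry over to every 4-substituted benzyl ring. No evidence is available to explain these differences. The compounds shown leave open whether a carboxylic acid or an amine in place of the cyano group would keep the low number of compound 1.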